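Bromo removal from the 4-bromophenyl group

The source may hold more compounds than are shown below. What is called first, only, known or untested is meant among the compounds shown, and "the series" means these compounds.

Values in a functional assay on A549 cells (Homo sapiens) for antiproliferative activity, read by MTT assay, with a stated time of 48 h; on this read-out higher numbers stand for weaker inhibition and lower numbers for stronger inhibition:
- compound 1 `COc1ccc(/C=C/C(=O)Nc2cc(-c3ccc(Br)cc3)[nH]n2)cc1`: 820 nM
- compound 2 `O=C(/C=C/c1ccc(Br)cc1)Nc1cc(-c2ccc(Br)cc2)[nH]n1`: 1360 nM
- compound 3 `O=C(/C=C/c1ccccc1)Nc1cc(-c2ccc(Br)cc2)[nH]n1`: 1440 nM

Compound 2 lies in one band with the other two, with no separation on these numbers. The measured steps are a 1.7-fold higher number from compound 1 to compound 2 (0.22 log units; within the scatter) and a 1.8-fold higher number from compound 1 to compound 3 (0.24 log units; within the scatter).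

Compound 4 `O=C(/C=C/c1ccc(Br)cc1)Nc1cc(-c2ccccc2)[nH]n1` is the next analogue of compound 2: hydrogen in place of bromo on an aromatic carbon. This is hydrogen in place of bromo on an aromatic carbon, turning 4-bromophenyl to phenyl. Among the compounds with values here, no measured step touches that group. Within the data shown here, the closest precedent is the same exchange at the other bromo group, a 1.1-fold higher number from compound 2 to compound 3 (0.02 log units; within the scatter), so no step beyond the scatter is expected in this assay. The expected step is a 1.2-fold higher number from compound 2 to compound 4 (0.07 log units; within the scatter). For compound 4 the estimated value is 1600 nM, with an expected range of 750 nM to 3500 nM.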

Compound 4, half-maximal inhibitory concentration: 1460 nM
Compound 4: middle estimate off by 1.1-fold (0.04 log units), on the high side; measured number inside the range.
By their numbers in this assay, from the lowest: compounds 1, 2, 3 and 4 (each within the scatter of the next).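

At this position in this assay the change from 4-bromophenyl to phenyl gives a 1.1-fold higher number from compound 2 to compound 4 (0.03 log units; within the scatter) and opens no separation. For this pair, then, bromo para to a large group can be replaced by hydrogen without a step beyond the scatter. No available measurement offers an explanation for this result.

On these data alone, whether an amine or a carboxylic acid at this position would give a step beyond the scatter remains open. Also open, as far as these compounds go, is the outcome with a methoxy group here, on the ring that carries bromo in compound 1.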